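The source may hold more compounds than are shown below. What is called first, only, known or untested is meant among the compounds shown, and "the series" means these compounds.

Measured compounds in the series:
compound 1 `COc1cc2ncnc(NNC(=S)NC(=O)c3ccc(Cl)cc3)c2cc1OC`, 7530 nM
compound 2 `COc1cc2ncnc(NNC(=S)NC(=O)c3ccccc3F)c2cc1OC`, 12700 nM

Both numbers come from a functional assay on CNE-2 cells (Homo sapiens) for cytotoxicity, read by MTT assay, with a stated time of 72 h; on this read-out higher numbers stand for weaker inhibition and lower numbers for stronger inhibition. Compound 2 carries the highest number of the two; the only other measured point, compound 1, is separated from it by a 1.7-fold higher number from compound 1 to compound 2 (0.23 log units; within the scatter), a step that does not rise above the scatter. Compound 3 `COc1cc2ncnc(NNC(=S)NC(=O)c3ccc(F)cc3)c2cc1OC` is the next member, and the difference from compound 2 is 4-fluorophenyl in place of 2-fluorophenyl on a carbonyl carbon. Going by the values given here, no measured step moves a fluorine around the ring this way; the only step that bears on the change at all is the one from compound 1 to compound 2, which swaps one halogenated phenyl for another and stays within the scatter. On that basis compound 3 is expected to sit close to compound 2, with an estimated step of a 1.4-fold lower number from compound 2 to compound 3 (0.15 log units; within the scatter), leaning slightly toward the number of compound 1. The estimate for compound 3 is 9000 nM, with a range from 3500 nM to 24000 nM.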

Compound 3, half-maximal inhibitory concentration: 16100 nM
Beside the measured number, compound 3's estimate is 1.8-fold (0.25 log units) below it, within the range that was stated.
By their numbers in this assay, from the lowest: compounds 1, 2 and 3 (each within the scatter of the next, the first and the last beyond it).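

In this assay, 4-fluorophenyl in place of 2-fluorophenyl on the carbonyl carbon gives a 1.3-fold higher number from compound 2 to compound 3 (0.10 log units; within the scatter), so the two fluorophenyl groups cannot be told apart at this place in the series. With the 4-substituted phenyl kept, fluoro in place of chloro on an aromatic carbon gives a 2.1-fold higher number from compound 1 to compound 3 (0.33 log units; beyond the scatter), a modest step but the first in the series to lie beyond the scatter, which points to the identity of the halogen rather than the fluorine's place on the ring as the change that registers here. Nothing available accounts for either step.

Still open, from the compounds shown here alone, is whether the lower number seen with chloro carries over to a bromo group on the same ring. Going by these compounds, it is also open how an unsubstituted phenyl, or a phenyl bearing a methoxy group, a nitrile or an amine, would compare with compound 1 and compound 3.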